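A few compounds are considered here, and "the series" means these few. Any claim that something is new, unique, unknown or untested is made for them only; others in the source may bear on it.

The measured compounds:

Compound 1, `Nc1ccc2cccc(OCCC3CCCCC3)c2n1`, gives 808 nM in an assay on cells with melanin-concentrating hormone receptor 1 (Homo sapiens) as the target, read by radioligand binding; a lower number here means a stronger inhibitor, a higher number a weaker inhibitor.
Compound 2, `Nc1ccc2cccc(OCC3CCCO3)c2n1`, gives > 2000 nM in this assay, which is a limit of the assay and not a number.
Compound 3, `CC#CCCOc1cccc2ccc(N)nc12`, gives > 2000 nM in this assay, likewise a limit and not a number.

Compound 3 therefore stands at the weak end of what was measured: its value is only a limit, shared with compound 2, as the limit of > 2000 nM in this assay, at which 2 of the 3 values shown sit, records. The unmeasured compound 4, `CCCCCOc1cccc2ccc(N)nc12`, differs from compound 3 by propyl in place of prop-1-yn-1-yl on a saturated chain carbon, two bonds along the chain from an oxygen on an aromatic ring; the triple bond of compound 3 is gone and a saturated chain remains.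

Among the measured compounds shown here, only one measured step reaches compound 3 with a readable size: an at least 2.4-fold higher number from compound 1 to compound 3 (0.39 log units; beyond the scatter), which shows that a large saturated ring beats the alkyne in this place. The other step, a step that the two limits leave unreadable from compound 2 to compound 3, gives no size. For the measured compounds named here, no measured pair compares a saturated straight chain with an alkyne, so the direction for compound 4 rests on the single comparison with compound 1. A small gain over compound 3 in this assay seems possible for compound 4, but a step that the limit leaves unreadable from compound 3 to compound 4 is the expectation, and a limit remains likely. Compound 4 is thus expected to give about 2500 nM, within 700 nM to 9000 nM.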

Compound 4, half-maximal inhibitory concentration: 580 nM
Beside the measured number, compound 4's estimate is 4.3-fold (0.63 log units) above it, outside the stated range (below it).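

At this place, on a saturated chain carbon, two bonds along the chain from an oxygen on an aromatic ring, propyl in place of prop-1-yn-1-yl gives an at least 3.4-fold lower number from compound 3 to compound 4 (0.53 log units; beyond the scatter) in this assay, so the triple bond alone, with the heavy-atom count unchanged, separates a limit from a readable value. The large saturated ring of compound 1 also turns out not to be required, since propyl in place of cyclohexyl gives a 1.4-fold lower number from compound 1 to compound 4 (0.14 log units; within the scatter), and no order can be drawn between the straight chain and the ring. Butyl in place of oxolan-2-yl gives an at least 3.4-fold lower number from compound 2 to compound 4 (0.53 log units; beyond the scatter), extending the advantage of the saturated chain over a second group, though this step and the one from the alkyne are bounded on one side only: the limit of > 2000 nM in this assay, at which 2 of the 4 values shown sit.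

As far as these compounds go, how far compound 2 and compound 3 actually lie beyond that limit remains open, so the full size of both steps is unknown. Also open, from the compounds shown here alone, is whether a longer chain, or an amine or a carboxylic acid carried on the chain, would keep, improve or lose the value seen with the butyl and cyclohexyl-bearing chains.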